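Para-substituent changes on the anilino ring of the shared core

The source may hold more compounds than are shown below. What is called first, only, known or untested is meant among the compounds shown, and "the series" means these compounds.

Compound 1 `Cc1cnc(Nc2ccc(S(C)(=O)=O)cc2)nc1Nc1nc2ccccc2s1` carries a methylsulfonyl group on its anilino ring; in a functional assay on HCT-116 cells (Homo sapiens) for antiproliferative activity, read by MTT assay, with a stated time of 48 h (a higher number here means a weaker inhibitor, a lower number a stronger inhibitor), compound 1 gives 760 nM. Compound 2 `Cc1cnc(Nc2ccc(S(N)(=O)=O)cc2)nc1Nc1nc2ccccc2s1` has a sulfamoyl group in the same place, and in this assay compound 2 gives 1660 nM; the step is a 2.2-fold higher number from compound 1 to compound 2 (0.34 log units; beyond the scatter). Compound 3 `Cc1cnc(Nc2ccc(Cl)cc2)nc1Nc1nc2ccccc2s1` replaces the sulfonyl-type group with chloro. In this assay compound 3 gives > 50000 nM, which is a limit of the assay and not a number. Compound 3 therefore stands at the upper edge of the measured set, at the limit of > 50000 nM in this assay, at which 1 of the 3 values shown sits. The steps into it are an at least 65-fold higher number from compound 1 to compound 3 (1.81 log units; beyond the scatter) and an at least 30-fold higher number from compound 2 to compound 3 (1.47 log units; beyond the scatter), both large.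

Compound 4 `Cc1cnc(Nc2ccc(F)cc2)nc1Nc1nc2ccccc2s1` differs from compound 3 by fluoro in place of chloro on an aromatic carbon. For the measured compounds named here, no measured step compares two halogens, so the two large steps from compound 1 and compound 2 into compound 3 are the only bearing evidence, and they concern the loss of the sulfonyl-type group rather than the halogen itself. A small halogen swap is not expected to recover what that loss cost. For compound 4 the estimate in this assay is 60000 nM, with a range from 20000 nM to 200000 nM. The step this estimate implies, a step that the limit leaves unreadable from compound 3 to compound 4, is expected to stay within the scatter, with compound 4 most likely again reported only as a limit.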

Compound 4, half-maximal inhibitory concentration: > 50000 nM
Compound 4 was reported as a limit; the forecaster's own chance of this, stated with the estimate: 75%; the middle value does not contradict the limit.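

In this assay compound 4 gives > 50000 nM, which is a limit of the assay and not a number, and the set now holds a second compound at that limit: the limit of > 50000 nM in this assay, at which 2 of the 4 values shown sit. The large drop seen with chloro is therefore not specific to chloro, since the fluoro compound also gives large steps, an at least 65-fold higher number from compound 1 to compound 4 (1.81 log units; beyond the scatter) and an at least 30-fold higher number from compound 2 to compound 4 (1.47 log units; beyond the scatter). With both halogen compounds reported only as limits, the step between them cannot be read, and no order of chloro and fluoro can be drawn from these data.

As far as these compounds go, what remains open is how much of the activity depends on the sulfonyl-type group itself, and whether a carboxylic acid, a primary carboxamide or an amine at this position would give a value in the range of compound 1 and compound 2 or stay at the limit like compound 3 and compound 4. From the compounds shown here alone, how far the two halogen compounds lie beyond the limit also stays open, so any difference between them could only be seen in a measurement that gives a number.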